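The source may report more compounds than this note shows. Statements on the series, on what has been measured and on what is new or still open speak of the compounds shown alone.

Compound 1, `S=C(NCc1cccnc1)SCCc1nc2ccccc2s1`: 9710 nM
Compound 2, `S=C(NCc1cccnc1)SCCc1nnc(-c2ccccc2)o1`: 2770 nM

Of the compounds shown here, two have been measured in a functional assay on MDA-MB-468 cells (Homo sapiens) for cytotoxicity, read by resazurin assay, with a stated time of 72 h; on this read-out lower numbers stand for stronger inhibition and higher numbers for weaker inhibition. Compound 2 stands at the lowest of the two numbers; its nearest neighbour is compound 1, whose number is higher by a margin beyond the usual scatter, so compound 2 is the more potent of the pair on this read-out.

Compound 3, `S=C(NCc1cccnc1)SCCc1nnc(-c2cccnc2)o1`, is not yet measured. It differs from compound 2 in one place: pyridin-3-yl in place of phenyl on an aromatic carbon.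

Among the compounds with values here, no step between measured compounds covers this kind of exchange, so there is nothing among the measured compounds to say which way, if at all, the number should move. The group that leaves and the group that enters are the same size, and the change is confined to a single ring position. The account therefore expects no step beyond the scatter from compound 2 to compound 3, that is a 1.1-fold higher number from compound 2 to compound 3 (0.03 log units; within the scatter).

On that basis compound 3 is estimated to give about 3000 nM in this assay, within a range from 1200 nM to 8000 nM.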

Compound 3, half-maximal inhibitory concentration: 3160 nM
Compound 3: the middle estimate sits 1.1-fold (0.02 log units) below what was measured; low and high end bracket the measured number.
By their numbers in this assay, from the lowest: compounds 2 and 3 (each within the scatter of the next); then compound 1.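

In this assay, putting pyridin-3-yl in place of phenyl on the aromatic carbon of the five-membered aromatic ring with 2 nitrogen and 1 oxygen gives a 1.1-fold higher number from compound 2 to compound 3 (0.06 log units; within the scatter), so the assay does not separate the two compounds. Within the data shown here, this is the first exchange read at this position, and it shows that a six-membered aromatic ring with 1 hetero atom and 1 hydrogen-bond acceptor can stand there in place of a ring of carbon only, with no step beyond the scatter in this pair. No measurement is at hand that would account for this result.

The compounds shown leave open whether the place of the ring nitrogen matters, as it could be tested with pyridin-2-yl or pyridin-4-yl on the same carbon. They also leave open whether this position would respond to a group of another kind, such as an amine, a carboxylic acid or a longer alkyl chain, since both groups read so far are six-membered aromatic rings of the same size.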